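Naphthalene to Trifluoromethoxyphenyl: Expected Cytotoxicity of Compound 4

The compounds below may be only part of what the source reports. "The series", "measured", "known", "first", "only" and "open" are said of these compounds alone.

Compound 1 `COc1cc(F)cc(-c2ccc(C(=O)N(Cc3cccc(OCCCCCC(=O)O)c3)C(C)C)cc2)c1` in an ADME assay on BJ cells (Homo sapiens) for cytotoxicity, read by CellTiter-Glo and resazurin assay, with a stated time of 72 h (on this read-out lower numbers stand for an effect already at smaller amounts and higher numbers for an effect only at larger amounts of compound), compound 1 gives > 26000 nM, a limit of the assay.
Compound 2 `CC(C)N(Cc1cccc(OCCCCCC(=O)O)c1)C(=O)c1ccc(-c2cccc(Br)c2)cc1` in this assay compound 2 gives > 26000 nM, a limit of the assay.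
Compound 3 `CCOC(=O)CCCCCOc1cccc(CN(C(=O)c2ccc(-c3ccc4ccccc4c3)cc2)C(C)C)c1` in this assay compound 3 gives > 26000 nM, a limit of the assay.

Compound 3 therefore stands where every measured compound stands: the limit of > 26000 nM in this assay, at which 3 of the 3 values shown sit. None of the three gives a true number, only the note that no effect appeared up to the highest amount tested.

The new compound is compound 4 `CCOC(=O)CCCCCOc1cccc(CN(C(=O)c2ccc(-c3cccc(OC(F)(F)F)c3)cc2)C(C)C)c1`. It differs from compound 3 in one place: 3-(trifluoromethoxy)phenyl in place of naphthalen-2-yl on an aromatic carbon.

Among the compounds with values here, only one measured step between neighbours exists, and it is a step that the two limits leave unreadable from compound 1 to compound 2. It gives no readable size, so it cannot say how large a change of the aryl group moves this read-out. With all three measured compounds at the same limit, the expectation is that compound 4 also shows no effect within the tested range in this assay, an expected step that the limit leaves unreadable from compound 3 to compound 4, which means no step beyond the scatter. Compound 4 is estimated at 40000 nM, expected to fall between 15000 nM and 120000 nM.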

Compound 4, half-maximal effective concentration: > 26000 nM
Compound 4 ended at the assay's limit; the forecaster's own chance of this, stated with the estimate: 85%; the middle value is on the limit's open side.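

Compound 3 and compound 4 both give only a limit of the assay in this assay and the step between them cannot be read. The compounds shown leave open at what amount, if any, each would affect these cells, and whether 3-(trifluoromethoxy)phenyl in place of naphthalen-2-yl changes that amount.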